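Swapping the hydantoin for a triazole on the ether side chain

The source may report more compounds than this note shows. Statements on the series, on what has been measured and on what is new or still open speak of the compounds shown alone.

Of the compounds shown here, three sharing one core have been tested in a functional assay (aorta) with Rattus norvegicus as the target; a higher number here means a weaker inhibitor, a lower number a stronger inhibitor. Compound 1 `CCO/C(O)=C1\C(COCCn2c(C)nc(C)c2C)=NC(C)=C(C(=O)OC)C1c1ccccc1Cl` gives 5.01 nM, compound 2 `CCO/C(O)=C1\C(COCCn2cnc3ccccc32)=NC(C)=C(C(=O)OC)C1c1ccccc1Cl` gives 20 nM, and compound 3 `CCO/C(O)=C1\C(COCCN2C(=O)CNC2=O)=NC(C)=C(C(=O)OC)C1c1ccccc1Cl` gives 31.6 nM. Compound 1 is the strongest of the three: the change from a trimethylimidazole to a benzimidazole brought a 4.0-fold higher number from compound 1 to compound 2 (0.60 log units; beyond the scatter), and the change to a hydantoin brought a 6.3-fold higher number from compound 1 to compound 3 (0.80 log units; beyond the scatter). Compound 3 carries the highest of the three numbers, yet it cannot be told apart from compound 2, since a 1.6-fold higher number from compound 2 to compound 3 (0.20 log units; within the scatter) stays within the scatter.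

Compound 4 `CCO/C(O)=C1\C(COCCn2ccnn2)=NC(C)=C(C(=O)OC)C1c1ccccc1Cl` is not yet measured. Compared with compound 3, the change is 1H-1,2,3-triazol-1-yl in place of 2,5-dioxoimidazolidin-1-yl on a saturated chain carbon, two bonds along the chain from an oxygen on a saturated carbon. The two aromatic five-membered heterocycles already seen, in compound 1 and compound 2, both gave lower numbers than the hydantoin of compound 3, so a modest move toward stronger inhibition is expected for compound 4, roughly a 2.1-fold lower number from compound 3 to compound 4 (0.32 log units; beyond the scatter). Compound 4 is therefore estimated at 15 nM in this assay, within a range from 5 nM to 45 nM.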

Compound 4, half-maximal inhibitory concentration: 15.9 nM
Beside the measured number, compound 4's estimate is 1.1-fold (0.03 log units) below it; the range from low to high includes it.
By their numbers in this assay, from the lowest: compound 1; then compounds 4, 2 and 3 (each within the scatter of the next).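

In this assay the 1H-1,2,3-triazol-1-yl group, with no hydrogen-bond donor and fewer heavy atoms, cannot be told apart from the hydantoin, since a 2.0-fold lower number from compound 3 to compound 4 (0.30 log units; within the scatter) stays within the scatter. It also cannot be told apart from the benzimidazole, as a 1.3-fold lower number from compound 2 to compound 4 (0.10 log units; within the scatter) is likewise within the scatter, so this place on the chain accepts these three quite different rings with no clear difference among them. Only the trimethylimidazole stands apart, as a 3.2-fold higher number from compound 1 to compound 4 (0.50 log units; beyond the scatter) shows, so having an aromatic five-membered ring here does not by itself reach the number of compound 1.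

Still open, as far as these compounds go, is whether a dimethylamino group, a carboxylic acid, or a longer chain carrying the trimethylimidazole would match compound 1. No evidence here explains why compound 1 stands apart.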